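Methoxy for Methyl in Two Matched Pairs

This account rests on a few compounds, and the source may have more. Where it says the series, first, only, none or still open, it means among the compounds named here.

Compound 3 `C=C1C[C@]23C[C@@]1(O)CC[C@H]2c1ccc(O)c(C)c1[C@@H]3Cn1cc(-c2ccc(C)cc2)nn1` and compound 2 `C=C1C[C@]23C[C@@]1(O)CC[C@H]2c1ccc(O)c(C)c1[C@@H]3Cn1cc(-c2ccc(OC)cc2)nn1` share one core and differ only by methoxy in place of methyl on an aromatic carbon. In a functional assay on SW480 cells (Homo sapiens) for cytotoxicity, read by MTT assay, with a stated time of 4 days (a lower number here means a stronger inhibitor, a higher number a weaker inhibitor), compound 3 gives > 20000 nM, which is a limit of the assay rather than a number. Compound 2 likewise gives > 20000 nM, also a limit. The step between them is therefore a step that the two limits leave unreadable from compound 3 to compound 2. Compound 1 `Cc1ccc(-c2cn(C[C@H]3c4c(ccc(O)c4C)[C@@H]4CC[C@@]5(C)C[C@]43CC5=O)nn2)cc1` rests on another core; the difference between the two cores is not broken down here. In this assay compound 1 gives > 20000 nM, again a limit. For the measured compounds named here, all values known so far sit at the limit of > 20000 nM in this assay, at which 3 of the 3 values shown sit. The same change, (methoxy in place of methyl on an aromatic carbon), leads from compound 1 to compound 4 `COc1ccc(-c2cn(C[C@H]3c4c(ccc(O)c4C)[C@@H]4CC[C@@]5(C)C[C@]43CC5=O)nn2)cc1`, not yet measured. Because compound 1 sits at > 20000 nM, the step is expected to be a step that the limit leaves unreadable from compound 1 to compound 4. Compound 4 is expected near 30000 nM, between 15000 nM and 60000 nM, most likely reported again as a limit.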

Compound 4, half-maximal inhibitory concentration: > 20000 nM
Compound 4 ended at the assay's limit; the forecaster's own chance of this, stated with the estimate: 85%; the middle value does not contradict the limit.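

No new step can be read from compound 1 and compound 4, since in this assay both stop at a limit rather than a number: the limit of > 20000 nM in this assay, at which 4 of the 4 values shown sit. The compounds shown leave open whether methoxy in place of methyl changes cytotoxicity at all.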